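Chloro to trifluoromethyl on the benzyl ring

The compounds below may be only part of what the source reports. "The series", "measured", "known", "first", "only" and "open" are said of these compounds alone.

Values in an assay for inhibition of acyl-CoA desaturase 1 (Rattus norvegicus) (on this read-out lower numbers stand for stronger inhibition and higher numbers for weaker inhibition), so far:
compound 1 `Cn1ccc(NC(=O)c2cn(Cc3cccc(Cl)c3)cn2)n1`: 57 nM
compound 2 `Cn1ccc(NC(=O)c2cn(Cc3ccc(Cl)c(C(F)(F)F)c3)nn2)n1`: 33 nM
compound 3 `Cn1ccc(NC(=O)c2ncn(Cc3cccc(C(F)(F)F)c3)n2)n1`: 113 nM

Compound 1 stands second highest of the three numbers. Compound 2 lies somewhat lower and compound 3 somewhat higher, yet both gaps fall within the scatter, so no order among the three can be read.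

Compound 4 `Cn1ccc(NC(=O)c2cn(Cc3cccc(C(F)(F)F)c3)cn2)n1` differs from compound 1 by trifluoromethyl in place of chloro on an aromatic carbon. Going by the values given here, no measured pair shows this exact change on the same core: compound 3 carries trifluoromethyl on a different core, compound 2 carries chloro and trifluoromethyl together. On that basis the step in this assay is expected to be none beyond the scatter, direction open.

Compound 4 is estimated at 60 nM, range 25 nM to 150 nM, which would mean an expected 1.1-fold higher number from compound 1 to compound 4 (0.02 log units; within the scatter).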

Compound 4, half-maximal inhibitory concentration: 11 nM
Estimate against measurement, compound 4: 5.5-fold (0.74 log units) above, outside the stated range (below it).
By their numbers in this assay, from the lowest: compound 4; then compounds 2, 1 and 3 (each within the scatter of the next, the first and the last beyond it).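

In this assay, going by these compounds alone, the aromatic carbon meta to a large group proves sensitive to the choice of substituent: trifluoromethyl in place of chloro on the shared core gives a 5.2-fold lower number from compound 1 to compound 4 (0.71 log units; beyond the scatter) as the first single-place step. Compound 1, compound 2 and compound 3 could not show this, as no two of them differ in one place only. Nothing at hand accounts for the step.

Going by these compounds, whether the same change carries over to the cores of compound 2 and compound 3 stays open. So does how a methoxy group, a nitrile or an amine would fare on this aromatic carbon.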